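This account rests on a few compounds, and the source may have more. Where it says the series, first, only, none or still open, it means among the compounds named here.

Measured so far:
compound 1 `CSS[C@H]1C(O)[C@@H](CO)O[C@H]1n1ccc(=O)[nH]c1=O` with 320000 nM
compound 2 `CSS[C@H]1C(O)[C@@H](CO)O[C@H]1n1ccc(N)nc1=O` with 350000 nM

In a functional assay on L1210 cells (Mus musculus) for antiproliferative activity (a lower number here means a stronger inhibitor, a higher number a weaker inhibitor), compound 1 gives 320000 nM, and compound 2 gives 350000 nM. On these two numbers compound 2 and compound 1 cannot be told apart: the gap between them lies within the scatter, and both sit in the weak range of this assay.

Compound 3 `Nc1ccn([C@@H]2O[C@H](CO)C(O)[C@@H]2S)c(=O)n1` differs from compound 2 in one place: hydrogen in place of methylsulfanyl on a sulfur. Among the compounds with values here, no measured pair in this small set shows this exchange, so nothing in the numbers fixes its size or direction. The step from compound 2 to compound 3 is expected to be modest and, if anything, toward a lower number, as a 2.3-fold lower number from compound 2 to compound 3 (0.37 log units; beyond the scatter), with a fair chance that it stays within the scatter. Compound 3 is therefore expected to give about 150000 nM in this assay, within a range from 30000 nM to 500000 nM.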

Compound 3, half-maximal inhibitory concentration: 670000 nM
Estimate against measurement, compound 3: 4.5-fold (0.65 log units) below, and the stated range ends below it.
By their numbers in this assay, from the lowest: compounds 1, 2 and 3 (each within the scatter of the next, the first and the last beyond it).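

In this assay, hydrogen in place of methylsulfanyl on a sulfur gives a 1.9-fold higher number from compound 2 to compound 3 (0.28 log units; within the scatter) and so does not separate compound 3 from compound 2. Within the data shown here, this is the first reading of any change at this position: on this single pair, the sulfanyl group and the (methylsulfanyl)sulfanyl group cannot be told apart, and compound 3 stays in the weak range of compound 2. One pair fixes no general size or direction for this exchange.

On these data alone, whether a longer chain on this sulfur, such as ethylsulfanyl, or an amine or a hydroxyl in place of the sulfanyl group would move the number beyond the scatter stays open, as does the same exchange on the core of compound 1. No measurement shown here accounts for this result.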